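From 4-chlorophenyl to 3-chlorophenyl on an oxygen

The source may hold more compounds than are shown below. What is called first, only, known or untested is meant among the compounds shown, and "the series" means these compounds.

Compound 1 `COc1cc(/C=C/c2ccc(C3=C(c4ccc(O)cc4)C4CC(S(=O)(=O)Oc5ccc(Br)cc5)C3O4)cc2)cc(OC)c1` gives > 100000 nM as a limit
Compound 2 `CCc1ccccc1OS(=O)(=O)C1CC2OC1C(c1ccc(/C=C/c3cc(OC)cc(OC)c3)cc1)=C2c1ccc(O)cc1` gives 49800 nM as a number
Compound 3 `O=S(=O)(Oc1ccc(Cl)cc1)C1CC2OC1C(c1ccc(/C=C/c3cc(O)cc(O)c3)cc1)=C2c1ccc(O)cc1` gives 17900 nM as a number

In a functional assay on MCF7 cells (Homo sapiens) for antiproliferative activity, read by MTT assay, with a stated time of 72 h (a higher number here means a weaker inhibitor, a lower number a stronger inhibitor), compound 3 gives 17900 nM as the lowest number shown, and compound 2 gives 49800 nM as the nearest one, higher by more than the scatter. Compound 1 reads > 100000 nM as a limit of the assay and not a number.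

The difference 3-chlorophenyl in place of 4-chlorophenyl on an oxygen puts 3-chlorophenyl in place of 4-chlorophenyl on an oxygen, and compound 4 `O=S(=O)(Oc1cccc(Cl)c1)C1CC2OC1C(c1ccc(/C=C/c3cc(O)cc(O)c3)cc1)=C2c1ccc(O)cc1` keeps the same atoms, joined differently. Within the data shown here, the one measured step on that oxygen is an at least 2.0-fold lower number from compound 1 to compound 2 (0.30 log units; that floor lies within the scatter) and it starts from a limit, with a floor inside the scatter. That step moves no chlorine, so it gives no size for this change. Compound 3 stands at 17900 nM in this assay, and only a small step is therefore expected for this change. The expected step is a 1.1-fold higher number from compound 3 to compound 4 (0.05 log units; within the scatter) and it stays small. Compound 4 is estimated at 20000 nM with 8000 nM to 60000 nM as the expected range.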

Compound 4, half-maximal inhibitory concentration: 12900 nM
Estimate against measurement, compound 4: 1.6-fold (0.19 log units) above; the range from low to high includes it.
By their numbers in this assay, from the lowest: compounds 4 and 3 (each within the scatter of the next); then compound 2. At a limit, above all of these: compound 1.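

In this assay, the change from 4-chlorophenyl to 3-chlorophenyl on the oxygen bound to the sulfonyl sulfur gives a 1.4-fold lower number from compound 3 to compound 4 (0.14 log units; within the scatter). Among these compounds, this is the first step at this position with a number at both ends, and it shows that, for this pair, moving the chlorine around the ring leaves the reading within the scatter, so the position of the chlorine does not separate compound 3 from compound 4 here. No measurement shown explains why the two compounds read alike.

The compounds shown leave open whether the same holds on the core of compound 2, where the only step on this oxygen starts from a limit. They also leave open how this assay would respond to an amine or a carboxylic acid in place of the chlorine on this ring.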